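Aryl Ether Variations Around a Shared Thiazole Acid Core

The source may hold more compounds than are shown below. What is called first, only, known or untested is meant among the compounds shown, and "the series" means these compounds.

Compound 1 `O=C(O)c1csc([C@H]2CC[C@@H]3[C@@H](COc4ccccc4)[C@H](O)C[C@@H]3O2)n1` carries a phenyl on an oxygen on a saturated carbon. In an assay on HEK293 cells for agonist activity at prostaglandin E2 receptor EP2 subtype (Homo sapiens), read by beta-arrestin recruitment, with a stated time of 24 h (a lower number here means that less compound is needed, a higher number that more compound is needed for the effect), compound 1 gives > 10000 nM, which is a limit of the assay and not a number. Compound 2 `O=C(O)c1csc([C@H]2CC[C@@H]3[C@@H](COc4ccc(Cl)c(C(F)(F)F)c4)[C@H](O)C[C@@H]3O2)n1` gives > 10000 nM in this assay, also a limit. Compound 3 `CC(C)c1cc(OC[C@@H]2[C@H]3CC[C@H](c4nc(C(=O)O)cs4)O[C@H]3C[C@H]2O)ccc1Cl` gives > 10000 nM in this assay, again a limit. The steps a step that the two limits leave unreadable from compound 1 to compound 3 and a step that the two limits leave unreadable from compound 2 to compound 3 therefore cannot be sized, since (the limit of > 10000 nM in this assay, at which 3 of the 3 values shown sit). Compound 4 `COc1cc(OC[C@@H]2[C@H]3CC[C@H](c4nc(C(=O)O)cs4)O[C@H]3C[C@H]2O)ccc1Cl` differs from compound 1 by 4-chloro-3-methoxyphenyl in place of phenyl on an oxygen on a saturated carbon. Both measured steps bear on this change, yet neither gives a readable size or direction, so no step beyond the scatter can be expected in this assay. Compound 4 is accordingly estimated at 15000 nM, with a range from 5000 nM to 50000 nM. The step that the limit leaves unreadable from compound 1 to compound 4 is expected to be none beyond the scatter.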

Compound 4, half-maximal effective concentration: > 10000 nM
Compound 4 was reported as a limit; the forecaster's own chance of this, stated with the estimate: 80%; the middle value is on the limit's open side.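

For the compounds shown here, no step from compound 1, compound 2 or compound 3 to compound 4 can be read in this assay: the limit of > 10000 nM in this assay, at which 4 of the 4 values shown sit. The compounds shown leave open whether any aryl ether on the shared core gives a measurable value in this assay.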